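Antiproliferative read-out: chromone amides, cyclohexyl to phenylsulfonyl

The compounds below may be only part of what the source reports. "The series", "measured", "known", "first", "only" and "open" are said of these compounds alone.

Measured so far:
- compound 1 `COc1ccc(-c2c(Cl)c(=O)c3c(OC)cc(OC)cc3n2S(=O)(=O)c2ccc(OC)cc2)cc1`: 90000 nM
- compound 2 `COc1cc(OC)c2c(=O)cc(C(=O)Nc3ccc(C4CCCCC4)cc3)[nH]c2c1`: 36200 nM

In an ADME assay on BJ cells (Homo sapiens) for antiproliferative activity, with a stated time of 72 h (on this read-out higher numbers stand for an effect only at larger amounts of compound and lower numbers for an effect already at smaller amounts), compound 1 gives 90000 nM and compound 2 gives 36200 nM. Compound 2 therefore stands at the lower of the two numbers, and its gap to compound 1 lies beyond the usual scatter. The two compounds differ in many places at once, so their values say nothing about any single change.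

Compound 3 `COc1cc(OC)c2c(=O)cc(C(=O)Nc3ccc(S(=O)(=O)c4ccccc4)cc3)[nH]c2c1` is not yet measured. It keeps the whole core and amide of compound 2 and differs in one place: phenylsulfonyl in place of cyclohexyl on an aromatic carbon. Within the data shown here, no measured pair shows what this particular exchange does, so the expectation rests on compound 2 alone. The step from compound 2 to compound 3 is expected to be small, a 1.2-fold higher number from compound 2 to compound 3 (0.09 log units; within the scatter), with no clear direction beyond the scatter. For compound 3 the estimate in this assay is 45000 nM, within 12000 nM to 160000 nM.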

Compound 3, half-maximal effective concentration: > 70600 nM
Compound 3 ended at the assay's limit; the forecaster's own chance of this, stated with the estimate: 15%; middle value at least 1.5-fold (0.19 log units) away from the limit.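

In this assay, phenylsulfonyl in place of cyclohexyl on an aromatic carbon, para to a large group, gives an at least 1.9-fold higher number from compound 2 to compound 3 (0.29 log units; that floor lies within the scatter). Among these compounds, this is the first one-place comparison at this position, but its true size stays unknown because compound 3 ended at a limit of the assay and not at a number: the limit of > 70600 nM in this assay, at which 1 of the 3 values shown sits. The step does show that replacing the non-aromatic carbon ring with an aromatic ring carrying hydrogen-bond acceptors gave no lower number here, although its floor alone does not separate the two compounds beyond the scatter.

Going by these compounds, it remains open whether an amine or a carboxylic acid on this aromatic carbon would shift the number from that of compound 2, at 36200 nM. Also open, on these data alone, is whether the same exchange would behave alike on another core.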